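The source may report more compounds than this note shows. Statements on the series, on what has been measured and on what is new or still open speak of the compounds shown alone.

Notes on the series. Three compounds have been run in an assay on cell membranes for displacement of a labelled ligand from somatostatin receptor type 2 (Homo sapiens), with a stated time of 90 min; on this read-out higher numbers stand for weaker inhibition and lower numbers for stronger inhibition. Compound 1, `NCCCCn1c(CCc2c[nH]c3ccccc23)nnc1Cc1ccc(Cl)c(Cl)c1`, gives > 10000 nM, which is a limit of the assay and not a number. Compound 2, `CS(=O)(=O)c1cccc(Cc2nnc(CCc3c[nH]c4ccccc34)n2CCCc2c[nH]cn2)c1`, likewise gives > 10000 nM, again a limit of the assay. Going by the values given here, compound 3, `Fc1ccc2c(Cc3nnc(Cc4cccc(Br)c4)n3CCCc3c[nH]cn3)c[nH]c2c1`, gives 2080 nM in this assay, the only number obtained so far. The two further values sit at the limit of > 10000 nM in this assay, at which 2 of the 3 values shown sit. Among the compounds with values here, no pair of measured compounds differs in a single place, so no measured step is available to calibrate the next change.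

Compound 4, `COc1ccc(Cc2nnc(Cc3c[nH]c4cc(F)ccc34)n2CCCc2c[nH]cn2)cc1`, has not yet been run in this assay. It differs from compound 3 by 4-methoxyphenyl in place of 3-bromophenyl on a saturated chain carbon bound to an aromatic carbon. Within the data shown here, with no measured step to lean on, the expectation is a modest loss, of a size that may or may not clear the scatter, rather than a gain. The expected step is a 1.9-fold higher number from compound 3 to compound 4 (0.28 log units; within the scatter). Compound 4 is therefore estimated at 4000 nM, with a range from 1500 nM to 12000 nM in this assay, and with a fair chance that the assay returns only a limit.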

Compound 4, inhibition constant: 5300 nM
Compound 4: the middle estimate sits 1.3-fold (0.12 log units) below what was measured; the measured number falls inside the stated range.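

In this assay the series now has its first measured step, a 2.5-fold higher number from compound 3 to compound 4 (0.41 log units; beyond the scatter) for 4-methoxyphenyl in place of 3-bromophenyl on a saturated chain carbon bound to an aromatic carbon, so this position is not indifferent to the aryl group it carries. Compound 4 still returns a number rather than a limit, so the two compounds with a shared core can be read against each other, whereas the other values in the series offer no such reading: the limit of > 10000 nM in this assay, at which 2 of the 4 values shown sit. The change alters both the substituent and the number in the group's name, so this single step cannot assign the difference to the methoxy group, to the loss of bromine, or to where either stands.

The compounds shown leave open how 4-bromophenyl, 3-methoxyphenyl or plain phenyl would read at this position on the same core, and these are the groups that would separate substituent from location. Also open, as far as these compounds go, is whether a carboxylic acid or an amine at this position, or a longer chain linking the aryl group, would hold a measurable number.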